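Difluorophenyl Swap on a Triazole-Linked Sulfonamide

The source may hold more compounds than are shown below. What is called first, only, known or untested is meant among the compounds shown, and "the series" means these compounds.

Of the compounds shown here, two sharing a bis-sulfonyl indole core have been tested in a functional assay on 3T3-L1 cells (Mus musculus) for inhibition, with a stated time of 20 min, tested at 20 uM; a lower number here means less inhibition, a higher number more inhibition at the concentration tested (going by the name of the read-out). Compound 1, `Cc1ccc(S(=O)(=O)N(Cc2cccc(F)c2F)Cc2cn(S(=O)(=O)c3ccc(F)cc3)c3ccccc23)cc1`, gives -35% in this assay. Compound 2, `COc1ccc(Cn2cc(CN(Cc3cn(S(=O)(=O)c4ccc(C)cc4)c4ccccc34)S(=O)(=O)c3ccc(C)cc3)nn2)c(OC)c1`, gives 7.6% in this assay, which is the higher of the two numbers, and its distance from compound 1 lies beyond the usual scatter. Compound 3, `Cc1ccc(S(=O)(=O)N(Cc2cn(Cc3cccc(F)c3F)nn2)Cc2cn(S(=O)(=O)c3ccc(C)cc3)c3ccccc23)cc1`, has not yet been measured. It differs from compound 2 in one place: 2,3-difluorophenyl in place of 2,4-dimethoxyphenyl on a saturated chain carbon bound to an aromatic nitrogen. Compound 1 carries the same difluorophenyl group, though on a different position of the shared core, and its value in this assay is the lower of the two measured. Compound 3 is therefore expected to sit somewhat below compound 2, with a step from a number 7.6 percentage points lower from compound 2 to compound 3 (within the scatter) that may not exceed the scatter. The value estimated for compound 3 in this assay is 0%, within a range from -30% to 25%.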

Compound 3, a percentage reported as inhibition, at one concentration (the size of the read-out at that concentration, not a potency): 71.5%
Beside the measured number, compound 3's estimate is 71.5 percentage points below it; the whole stated range lies below it.
By their numbers in this assay, from the lowest: compound 1; then compound 2; then compound 3.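

At this place, on a saturated chain carbon bound to an aromatic nitrogen, the choice of aryl group matters greatly in this assay: putting 2,3-difluorophenyl in place of 2,4-dimethoxyphenyl gives a number 63.9 percentage points higher from compound 2 to compound 3 (beyond the scatter) with the rest of the structure unchanged. For the compounds shown here, the earlier compounds offered no pair differing in one place, so this is the first single change that can be read, and it shows that this one substituent can carry a large shift in inhibition at the concentration tested. No measurement shown bears on why the exchange has this effect.

The compounds shown leave open whether the gain follows from the fluorine atoms or from the loss of the methoxy groups. Going by these compounds, how an unsubstituted phenyl, a 2,4-difluorophenyl or a pyridine would read at this place also remains open.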